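Isopropyl for 3-methoxyphenyl on the amide nitrogen

The compounds below may be only part of what the source reports. "The series", "measured", "known", "first", "only" and "open" are said of these compounds alone.

compound 1: `O=C1COc2ccc(-c3cccc(NS(=O)(=O)c4ccc(F)cc4)c3)cc2N1c1ccccc1` — 30300 nM
compound 2: `COc1cccc(N2C(=O)COc3ccc(-c4cnc(Cl)c(NS(=O)(=O)c5ccc(F)cc5)c4)cc32)c1` — > 40000 nM

In a functional assay on HepG2 cells (Homo sapiens) for antiproliferative activity, read by MTT assay, with a stated time of 72 h (a higher number here means a weaker inhibitor, a lower number a stronger inhibitor), compound 1 gives 30300 nM. For compound 2 the result is only a limit of the assay, > 40000 nM, which places it at the limit of > 40000 nM in this assay, at which 1 of the 2 values shown sits. Within the data shown here, no two measured compounds differ in a single place, so no measured step is available to anchor the size of a change. Compound 3 `CC(C)N1C(=O)COc2ccc(-c3cnc(Cl)c(NS(=O)(=O)c4ccc(F)cc4)c3)cc21` differs from compound 2 by isopropyl in place of 3-methoxyphenyl on an amide-type nitrogen in a ring. The step of a number no higher from compound 2 to compound 3 (the limit leaves the size open) is expected to be none beyond the scatter in either direction, with a second limit-only reading the most likely outcome in this assay. Compound 3 is estimated at 40000 nM, within a range from 15000 nM to 100000 nM.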

Compound 3, half-maximal inhibitory concentration: 21500 nM
Beside the measured number, compound 3's estimate is 1.9-fold (0.27 log units) above it; the measured number falls inside the stated range.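

On the amide-type nitrogen in a ring, isopropyl in place of 3-methoxyphenyl gives an at least 1.8-fold lower number from compound 2 to compound 3 (0.26 log units; that floor lies within the scatter) in this assay. This position therefore does not need the aromatic ring to give a numerical reading, since compound 3 gives 21500 nM. The size of the step stays open, and compound 2 provides only a limit of the assay: the limit of > 40000 nM in this assay, at which 1 of the 3 values shown sits.

As far as these compounds go, whether a longer chain, such as n-butyl, or a chain ending in an amine or a carboxylic acid on this nitrogen moves the number beyond the scatter remains open. From the compounds shown here alone, whether isopropyl acts the same way on the core of compound 1 also remains open.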